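Amine Nitrogen Substituent Swap in an Agonist Series

The source may report more compounds than this note shows. Statements on the series, on what has been measured and on what is new or still open speak of the compounds shown alone.

Three measured compounds share one core. Compound 1 `CC(C)(C)OC(=O)N1CCC(O[C@H]2CC[C@@H](Oc3ccc(S(C)(=O)=O)cc3)CC2)CC1` gives 120% in a functional assay on isolated protein for agonist activity at Glucose-dependent insulinotropic receptor (Homo sapiens), read by HTRF and cAMP accumulation; on this read-out higher numbers stand for larger maximal responses and lower numbers for smaller maximal responses. Compound 2 `CC(C)S(=O)(=O)c1cnc(O[C@H]2CC[C@H](OC3CCN(C(=O)OC(C)(C)C)CC3)CC2)cn1` gives 109% in this assay. Compound 3 `CC1(OC(=O)N2CCC(O[C@H]3CC[C@H](Oc4cnc(S(C)(=O)=O)cn4)CC3)CC2)CC1` gives 118% in this assay; this number sits between the other two, and its gaps to compound 1 and to compound 2 both lie within the usual scatter, so the three read as alike. Compound 4 `CS(=O)(=O)c1cnc(O[C@H]2CC[C@H](OC3CCN(CC4(C(F)(F)F)CC4)CC3)CC2)cn1` is not yet measured. It differs from compound 3 by (1-(trifluoromethyl)cyclopropyl)methyl in place of ((1-methylcyclopropyl)oxy)carbonyl on an amine nitrogen in a ring. Going by the values given here, no measured pair shows such a change, so nothing here tells how the group on the amine nitrogen in a ring affects the maximal response; the three numbers vary little across different groups at that place. The estimated step of a number 8 percentage points lower from compound 3 to compound 4 (within the scatter) is expected to remain within the scatter. Compound 4 is estimated at 110%, with a range from 85% to 130%.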

Compound 4, largest response reached (Emax), in percent of the reference or control that the assay uses: 116%
Estimate against measurement, compound 4: 6 percentage points below; measured number inside the range.
By their numbers in this assay, from the lowest: compounds 2, 4, 3 and 1 (each within the scatter of the next, the first and the last beyond it).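

Going by these compounds alone, this is the first matched pair at the amine nitrogen in a ring: replacing ((1-methylcyclopropyl)oxy)carbonyl with (1-(trifluoromethyl)cyclopropyl)methyl gives, in this assay, a number 2 percentage points lower from compound 3 to compound 4 (within the scatter). In this pair, the maximal response therefore does not depend on a carbonyl in the group at that nitrogen. Nothing available explains this tolerance. As far as these compounds go, it remains open whether the response would hold with a free secondary amine or a simple acetyl group at this nitrogen. A single pair also leaves open whether the same swap behaves alike on the other compounds.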